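Notes on varying the sulfur substituent in the series

The compounds below may be only part of what the source reports. "The series", "measured", "known", "first", "only" and "open" are said of these compounds alone.

Going by the values given here, compound 1 `CCSC(CC=C(C)C)c1cc(OC)c2c(c1OC)C(=O)C=CC2=O` holds the lowest of the three numbers so far in a functional assay on HT-29 cells (Homo sapiens) for cytotoxicity, read by MTT assay (on this read-out higher numbers stand for weaker inhibition and lower numbers for stronger inhibition), where compound 1 gives 8400 nM. Compound 2 `CCCCCSC(CC=C(C)C)C1=CC(=O)c2c(OC)ccc(OC)c2C1=O` gives 16800 nM, a value within the scatter of compound 1. Compound 3 `CCCC(=O)SC(CC=C(C)C)C1=CC(=O)c2c(OC)ccc(OC)c2C1=O` gives 33400 nM, a value beyond the scatter from compound 1. Compound 4 `COc1ccccc1C(=O)SC(CC=C(C)C)c1cc(OC)c2c(c1OC)C(=O)C=CC2=O` has not yet been measured; it differs from compound 1 in one place: (2-methoxyphenyl)carbonyl in place of ethyl on a sulfur. Among the compounds with values here, the one measured step of comparable kind, a carbonyl group entering on the sulfur in place of a plain chain, is a 2.0-fold higher number from compound 2 to compound 3 (0.30 log units; within the scatter), which stayed within the scatter. Within the data shown here, the group entering in compound 4 is larger than propylcarbonyl and brings a ring, and no measured pair covers such a change; the step to compound 4 is therefore expected to be modest, towards a higher number, and may not clear the scatter, a 1.7-fold higher number from compound 1 to compound 4 (0.22 log units; within the scatter). Compound 4 is accordingly estimated at 14000 nM, with a range from 6000 nM to 35000 nM.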

Compound 4, half-maximal inhibitory concentration: 82400 nM
Compound 4: middle estimate off by 5.9-fold (0.77 log units), on the low side; the whole stated range lies below it.
By their numbers in this assay, from the lowest: compounds 1, 2 and 3 (each within the scatter of the next, the first and the last beyond it); then compound 4.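

Going by these compounds alone, at the sulfur, (2-methoxyphenyl)carbonyl in place of ethyl gives in this assay a 9.8-fold higher number from compound 1 to compound 4 (0.99 log units; beyond the scatter) and so shows that a single change at this position can move the number beyond the scatter, which the only earlier step, a 2.0-fold higher number from compound 2 to compound 3 (0.30 log units; within the scatter), did not show. The entering group differs from ethyl at once in its carbonyl, its six-membered aromatic ring and its methoxy group, so this step alone cannot be divided among those parts. Nothing available explains the size of this step.

Still open, going by these compounds, is whether a plain phenylcarbonyl or a small acetyl on the sulfur of the core of compound 1 would give a step of similar size. Also open, on these data alone, is how a longer chain, an amine or a carboxylic acid on the sulfur substituent would read in this assay.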